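Para-substituent swap on the aryl tail: iodo to methoxy

The source may report more compounds than this note shows. Statements on the series, on what has been measured and on what is new or still open speak of the compounds shown alone.

In a functional assay on 1321-N1 cells for agonist activity at P2Y purinoceptor 2 (Homo sapiens), read by scintillation counting and inositol phosphate accumulation (a lower number here means that less compound is needed, a higher number that more compound is needed for the effect), compound 3 `O=c1[nH]/c(=N\OCCCc2ccc(I)cc2)ccn1[C@@H]1O[C@H](COP(=O)(O)OP(=O)(O)OP(=O)(O)O)[C@@H](O)[C@H]1O` gives 187 nM, the lowest number of the three, with compound 1 `O=c1[nH]/c(=N\OCCCCc2ccccc2)ccn1[C@@H]1O[C@H](COP(=O)(O)OP(=O)(O)OP(=O)(O)O)[C@@H](O)[C@H]1O` at 214 nM nearest and compound 2 `O=c1[nH]/c(=N\OCCOc2ccccc2)ccn1[C@@H]1O[C@H](COP(=O)(O)OP(=O)(O)OP(=O)(O)O)[C@@H](O)[C@H]1O` at 3400 nM furthest. The steps of a 1.1-fold lower number from compound 1 to compound 3 (0.06 log units; within the scatter) and a 16-fold higher number from compound 1 to compound 2 (1.20 log units; beyond the scatter) frame the series, and the step of an 18-fold lower number from compound 2 to compound 3 (1.26 log units; beyond the scatter) is the other large one. Compound 4 `COc1ccc(CCCO/N=c2/ccn([C@@H]3O[C@H](COP(=O)(O)OP(=O)(O)OP(=O)(O)O)[C@@H](O)[C@H]3O)c(=O)[nH]2)cc1` differs from compound 3 by methoxy in place of iodo on an aromatic carbon. Among the measured compounds shown here, only the step of a 1.1-fold lower number from compound 1 to compound 3 (0.06 log units; within the scatter) bears on the aromatic tail, and it stayed within the scatter when 4-iodophenyl replaced benzyl; no measured step compares methoxy with iodo. The expected step of a 1.4-fold higher number from compound 3 to compound 4 (0.14 log units; within the scatter) is therefore small and without direction beyond the scatter. Compound 4 is estimated at 260 nM, range 80 nM to 850 nM.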

Compound 4, half-maximal effective concentration: 47 nM
Estimate against measurement, compound 4: 5.5-fold (0.74 log units) above; the whole stated range lies above it.
By their numbers in this assay, from the lowest: compound 4; then compounds 3 and 1 (each within the scatter of the next); then compound 2.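

In this assay, the substituent on this aromatic carbon turns out to matter: methoxy in place of iodo gives a step beyond the scatter (a 4.0-fold lower number from compound 3 to compound 4 (0.60 log units; beyond the scatter)), which the earlier 4-iodophenyl for benzyl change did not. The 4-methoxyphenyl tail also improves on the benzyl-extended chain (a 4.6-fold lower number from compound 1 to compound 4 (0.66 log units; beyond the scatter)). Its margin over the phenoxy tail is wider still (a 72-fold lower number from compound 2 to compound 4 (1.86 log units; beyond the scatter)), so the lowest number of the four now sits with methoxy.

Nothing available accounts for the difference between methoxy and iodo. On these data alone, whether ethoxy, hydroxy or an amine on this carbon would follow methoxy remains open.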